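Moving the chlorine on the hydrazone ring

The source may hold more compounds than are shown below. What is called first, only, known or untested is meant among the compounds shown, and "the series" means these compounds.

Compound 1 `O=C(COc1cccc2ccccc12)N/N=C/c1ccc(Cl)cc1`: 100 ug/mL
Compound 2 `C/C(=N\NC(=O)COc1cccc2ccccc12)c1ccc(O)cc1O`: > 100 ug/mL

Of the compounds shown here, two have been measured in an ADME assay on HEL cells (Homo sapiens) for cytotoxicity; a higher number here means that more compound is tolerated, a lower number that less compound is tolerated. Compound 1 gives 100 ug/mL. Compound 2 gives > 100 ug/mL, which is a limit of the assay rather than a number. Compound 1 therefore stands on the only number shown; the other value is the limit of > 100 ug/mL in this assay, at which 1 of the 2 values shown sits. Among the compounds with values here, no step between measured compounds that differ in a single place is available, so nothing measured tells how a change of this kind shifts the read-out.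

Compound 3 `O=C(COc1cccc2ccccc12)N/N=C/c1cccc(Cl)c1` has not yet been measured. It differs from compound 1 in one place: 3-chlorophenyl in place of 4-chlorophenyl on a carbon with a double bond to nitrogen. The two compounds have the same atoms, joined differently, and the change leaves the shared core untouched.

Within the data shown here, for such a change, with no measured step to draw on, the expected step in this assay is none beyond the usual scatter, in no particular direction, which is what the estimated step of no change at the digits printed from compound 1 to compound 3 (within the scatter) means. Compound 3 is thus estimated at 100 ug/mL, with a range from 50 ug/mL to 200 ug/mL.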

Compound 3, minimum cytotoxic concentration: 100 ug/mL
The estimate for compound 3 equals the measured number at the digits printed, and the stated range covers the measured number.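

Within the data shown here, the first measured step between compounds that differ in one place in this assay reads no change at the digits printed from compound 1 to compound 3 (within the scatter), for 3-chlorophenyl in place of 4-chlorophenyl on a carbon with a double bond to nitrogen. The two compounds hold the same atoms, joined differently, and the shared core is the same in both, so this pair isolates where the chlorine sits on that ring. For these two chlorophenyl groups, then, the change in where the chlorine is attached does not show up as a difference in how much compound the cells tolerate, although a single pair sets no rule for other groups at this place.

Going by these compounds, whether a different group on this ring, such as an amine, a carboxylic acid or a methoxy group, would shift the read-out remains open. Compound 2 provides no number to set against this step, since its value is a limit: the limit of > 100 ug/mL in this assay, at which 1 of the 3 values shown sits.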